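A few compounds are considered here, and "the series" means these few. Any claim that something is new, unique, unknown or untested is made for them only; others in the source may bear on it.

In an ADME assay on Raji cells (Homo sapiens) for cytotoxicity, read by CellTiter-Glo and resazurin assay, with a stated time of 72 h (a higher number here means that more compound is needed for the effect, a lower number that less compound is needed), compound 1 `CCOC(=O)CCCCCOc1cccc(CN(C(=O)c2ccc(-c3ccc4[nH]ccc4c3)cc2)C(C)C)c1` gives only a limit, > 26000 nM. Compound 2 `CCOC(=O)CCCCCOc1cccc(CN(C(=O)c2ccc(-c3cc(OC)cc(OC)c3)cc2)C(C)C)c1` likewise gives only a limit, > 26000 nM. The step that the two limits leave unreadable from compound 1 to compound 2 is therefore not readable, since both values sit at the limit of > 26000 nM in this assay, at which 2 of the 2 values shown sit. Going by the values given here, compound 2 thus stands at the limit of this assay, together with the one other value shown. Compound 3 `CCOC(=O)CCCCCOc1cccc(CN(C(=O)c2ccc(-c3cccc(O)c3)cc2)C(C)C)c1` differs from compound 2 by 3-hydroxyphenyl in place of 3,5-dimethoxyphenyl on an aromatic carbon. No readable measured step bears on this change, so no direction can be expected in this assay; a limit again seems the most likely outcome. For compound 3 the value is estimated at 26000 nM, with a range of 8000 nM to 80000 nM. The expected step of a number no higher from compound 2 to compound 3 (the limit leaves the size open) is taken as none beyond the scatter.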

Compound 3, half-maximal effective concentration: > 26000 nM
Compound 3 was reported as a limit (the forecaster's own chance of this, stated with the estimate: 80%); the middle value sits exactly at the limit.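

Going by these compounds alone, compound 3, like compound 1 and compound 2, gives only a limit, so no step among the three can be read: the limit of > 26000 nM in this assay, at which 3 of the 3 values shown sit.

Going by these compounds, whether any group at this aromatic carbon gives a readable value in this assay remains open.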